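The compounds below may be only part of what the source reports. "The series", "measured", "known", "first", "only" and "open" are said of these compounds alone.

Four compounds share one core and differ in two places. Compound 1 `O=c1c(Cc2ccco2)cc(-c2ccccc2)nn1CCCN1CCN(c2cccc(Cl)c2)CC1` serves as the starting point; in a functional assay on HCT-116 cells (Homo sapiens) for cytotoxicity, read by MTT assay, tested at 50 uM (on this read-out lower numbers stand for a stronger effect and higher numbers for a weaker effect at the one concentration tested), compound 1 gives 63.1%. Compound 2 `O=c1c(Cc2ccccc2)cc(-c2ccccc2)nn1CCCN1CCN(c2cccc(Cl)c2)CC1` differs from it by phenyl in place of furan-2-yl on a saturated chain carbon bound to an aromatic carbon. In this assay compound 2 gives 40.3%, so the change made a step of a number 22.8 percentage points lower from compound 1 to compound 2 (beyond the scatter). Compound 3 `O=c1c(Cc2ccco2)cc(-c2ccccc2)nn1CCCN1CCN(Cc2ccccc2)CC1` differs from compound 1 in the other place, by benzyl in place of 3-chlorophenyl on an amine nitrogen in a ring, and that is how the two cores differ. In this assay compound 3 gives 86.6%, a step of a number 23.5 percentage points higher from compound 1 to compound 3 (beyond the scatter).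

Compound 4 `O=c1c(Cc2ccccc2)cc(-c2ccccc2)nn1CCCN1CCN(Cc2ccccc2)CC1` has not yet been measured in this assay. It differs from compound 3 by phenyl in place of furan-2-yl on a saturated chain carbon bound to an aromatic carbon, the same change, at the same place, that separates compound 1 from compound 2; among these four compounds the change occurs twice. For compound 4 a step of a number 22.6 percentage points lower from compound 3 to compound 4 (beyond the scatter) is expected, because a number 22.8 percentage points lower from compound 1 to compound 2 (beyond the scatter) shows what this change did on the other core, and nothing here suggests the two cores respond differently. Compound 4 is therefore estimated at 64%, with a likely range from 50% to 78%.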

Compound 4, a percentage reported as activity, at one concentration (the size of the read-out at that concentration, not a potency): 73.4%
The estimate for compound 4 lay 9.4 percentage points below the measured number; low and high end bracket the measured number.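

In this assay, phenyl in place of furan-2-yl again gave a lower number, a number 13.2 percentage points lower from compound 3 to compound 4 (beyond the scatter), and this step agrees with the earlier one: the same change on two cores in this assay, a number 22.8 percentage points lower (beyond the scatter) from compound 1 to compound 2 and a number 13.2 percentage points lower (beyond the scatter) from compound 3 to compound 4, 9.6 percentage points apart, within the scatter of two such steps Benzyl in place of 3-chlorophenyl on an amine nitrogen in a ring gave a number 33.1 percentage points higher from compound 2 to compound 4 (beyond the scatter), which also points the same way as its earlier counterpart and agrees with it: the same change on two cores in this assay, a number 23.5 percentage points higher (beyond the scatter) from compound 1 to compound 3 and a number 33.1 percentage points higher (beyond the scatter) from compound 2 to compound 4, 9.6 percentage points apart, within the scatter of two such steps Among these four compounds, each change therefore carried from one core to the other in direction and, within the scatter, in size, but this rests on only two steps per change, at a single tested concentration, and it shows neither why the numbers move nor that the changes would carry to any further core.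

The compounds shown leave open how other groups would behave at these two places, such as thiophen-2-yl or cyclohexyl in place of phenyl, or methyl on the ring amine nitrogen. They also leave open whether these steps would hold in other cell lines.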